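The source may report more compounds than this note shows. Statements on the series, on what has been measured and on what is new or still open speak of the compounds shown alone.

Working notes on the series. In a functional assay on U-373MG ATCC cells (Homo sapiens) for cytotoxicity, read by MTT assay, with a stated time of 72 h (a higher number here means a weaker inhibitor, a lower number a stronger inhibitor), compound 1 `CCOC(=O)c1sc(N2CCCC2)nc1Cl`, which also carries pyrrolidin-1-yl, reads > 100000 nM, a limit of the assay and not a number. Compound 2 `O=C(c1ccccc1)c1sc(N2CCCCC2)nc1Cl` gives 96000 nM and compound 3 `COC(=O)c1sc2nc(SC)sc2c1C` gives 92000 nM. These two values lie within the scatter of each other, so compound 3 stands level with compound 2 and neither can be ranked.

The next compound to be measured is compound 4 `COC(=O)c1sc2nc(N3CCCC3)sc2c1C`. It has pyrrolidin-1-yl in place of methylsulfanyl on an aromatic carbon, next to the ring nitrogen and next to the ring sulfur, with the rest of the core of compound 3 unchanged (pyrrolidin-1-yl in place of methylsulfanyl on an aromatic carbon).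

For the measured compounds named here, no two measured compounds differ in one place, so the size of this change has no direct measure. The starting point is compound 3 at 92000 nM, and no large move in either direction is expected from it. The estimate means a small step of a 1.3-fold lower number from compound 3 to compound 4 (0.12 log units; within the scatter), expected to stay within the scatter. A reading at the limit of this assay also remains possible. For compound 4 the expected value is 70000 nM, with an estimated range of 25000 nM to 100000 nM.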

Compound 4, half-maximal inhibitory concentration: 89000 nM
Beside the measured number, compound 4's estimate is 1.3-fold (0.10 log units) below it; the measured number falls inside the stated range.
By their numbers in this assay, from the lowest: compounds 4, 3 and 2 (each within the scatter of the next). At a limit, above all of these: compound 1.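

In this assay the series now has its first pair differing in one place: putting pyrrolidin-1-yl in place of methylsulfanyl on an aromatic carbon, next to the ring nitrogen and next to the ring sulfur, gives a 1.0-fold lower number from compound 3 to compound 4 (0.01 log units; within the scatter). At this position on this core, the open methylsulfanyl group and the five-membered non-aromatic ring therefore cannot be told apart by this read-out, and this single exchange gives no sign that the position controls the reading. Compound 1 remains the only compound reading at a limit, so compound 3 and compound 4 form a pair of numbers that can be compared directly: the limit of > 100000 nM in this assay, at which 1 of the 4 values shown sits.

Going by these compounds, it remains open whether an open-chain amine such as dimethylamino at this position, or a carboxylic acid in place of the methyl ester, would move the reading beyond the scatter. One exchange on one core also cannot show whether the same flat result would hold on the core of compound 1 or compound 2, or what, if anything, would give a much lower number in this assay.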